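The source may report more compounds than this note shows. Statements on the series, on what has been measured and on what is new or still open speak of the compounds shown alone.

Measured so far in a functional assay on the whole organism for antagonist activity, with Mus musculus as the target (on this read-out lower numbers stand for an effect already at smaller amounts and higher numbers for an effect only at larger amounts of compound), each entry being a limit of the assay and not a number:

Compound 1 `COC(=O)N(C)C(C)C#CCn1ccnc1`: > 100 mg/kg
Compound 2 `CCOC(=O)N(C)CC#CCn1ccnc1`: > 100 mg/kg
Compound 3 `CCOC(=O)N(C)C(C)C#CCN1CCCC1`: > 100 mg/kg

Compound 3 gives > 100 mg/kg, which is a limit and not a number. It has no better or worse place than the others, for the whole set stands at the limit of > 100 mg/kg in this assay, at which 3 of the 3 values shown sit.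

Compound 4 `CCOC(=O)N(C)C(C)C#CCn1ccnc1` differs from compound 3 in one place, with 1H-imidazol-1-yl in place of pyrrolidin-1-yl on a saturated chain carbon bound to a triple-bonded carbon. The entering group is not new to this set. Compound 1 also carries 1H-imidazol-1-yl, and its > 100 mg/kg is a limit. Compound 2 carries it too, and its > 100 mg/kg is likewise a limit.

Among the measured compounds shown here, no measured step gives a size for this change, so the expectation is for no shift beyond the usual scatter in either direction, and another limit is the most likely report. The step expected is a step that the limit leaves unreadable from compound 3 to compound 4. If a number is obtained, compound 4 is estimated at 120 mg/kg, with an expected range from 50 mg/kg to 300 mg/kg.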

Compound 4, dose for half-maximal effect: > 100 mg/kg
Compound 4 ended at the assay's limit (the forecaster's own chance of this, stated with the estimate: 70%); the middle value is on the limit's open side.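

In this assay compound 4 gives > 100 mg/kg as a limit and not a number. Among the compounds shown here, no step to compound 4 from compound 1, compound 2 or compound 3 can be read, because all four compounds share the same limit: the limit of > 100 mg/kg in this assay, at which 4 of the 4 values shown sit. The compounds shown leave open whether any of these changes shifts the dose needed, and by how much.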